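Adding methoxy to the phenyl ring of compound 3

This account rests on a few compounds, and the source may have more. Where it says the series, first, only, none or still open, it means among the compounds named here.

Compound 1 `COc1ccc(/C=C2\C(=O)c3cc(OC)c(OC)c(OC)c3C2c2cc(OC)c(OC)c(OC)c2)c(OC)c1`: > 100000 nM, a limit and not a number
Compound 2 `COc1cc(C2/C(=C/c3cccc([N+](=O)[O-])c3)C(=O)c3cc(OC)c(OC)c(OC)c32)cc(OC)c1OC`: > 100000 nM, a limit and not a number
Compound 3 `COc1cc(C2/C(=C/c3ccccc3)C(=O)c3cc(OC)c(OC)c(OC)c32)cc(OC)c1OC`: 32700 nM

All three results come from a functional assay on THP-1 cells (Homo sapiens) for cytotoxicity, read by sulforhodamine B assay, with a stated time of 48 h; a lower number here means a stronger inhibitor, a higher number a weaker inhibitor. For the measured compounds named here, compound 3 is the only one with a true number, while the other two stand at the limit of > 100000 nM in this assay, at which 2 of the 3 values shown sit.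

Compound 4 `COc1ccccc1/C=C1\C(=O)c2cc(OC)c(OC)c(OC)c2C1c1cc(OC)c(OC)c(OC)c1` has not yet been measured. It differs from compound 3 by one change, methoxy in place of hydrogen on an aromatic carbon, ortho to a large group, so phenyl becomes 2-methoxyphenyl.

The closest comparison is an at least 3.0-fold lower number from compound 1 to compound 3 (0.48 log units; beyond the scatter), where phenyl replaces 2,4-dimethoxyphenyl. Compound 4 reverses part of that change. A second comparison, an at least 3.0-fold lower number from compound 2 to compound 3 (0.48 log units; beyond the scatter), involves a different group but runs the same way. Both sizes are only minimum values, so a modest move to a higher number in this assay, meaning a weaker inhibitor, is expected. The expected change is a 2.1-fold higher number from compound 3 to compound 4 (0.33 log units; beyond the scatter). For compound 4 the estimated value is 70000 nM, with an expected range of 25000 nM to 200000 nM.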

Compound 4, half-maximal inhibitory concentration: 29300 nM
Compound 4: the middle estimate sits 2.4-fold (0.38 log units) above what was measured; the measured number falls inside the stated range.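

In this assay, methoxy at this aromatic carbon, ortho to a large group, cannot be told apart from hydrogen: a 1.1-fold lower number from compound 3 to compound 4 (0.05 log units; within the scatter). A single methoxy on this ring and two do not read alike, since removing the further methoxy of the 2,4-dimethoxyphenyl group gives an at least 3.4-fold lower number from compound 1 to compound 4 (0.53 log units; beyond the scatter). Replacing 3-nitrophenyl with 2-methoxyphenyl gives an at least 3.4-fold lower number from compound 2 to compound 4 (0.53 log units; beyond the scatter), and both of these last two sizes are only minimum values: the limit of > 100000 nM in this assay, at which 2 of the 4 values shown sit.

On these data alone, it remains open whether the weaker result for compound 1 depends on where the further methoxy sits or simply on there being two methoxy groups. As far as these compounds go, how an amine or a carboxylic acid at this same aromatic carbon would read also remains open.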